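Chloro for Hydrogen on the Phenyl Ring

The compounds below may be only part of what the source reports. "The series", "measured", "known", "first", "only" and "open" are said of these compounds alone.

Of the compounds shown here, three sharing one core have been measured in an assay on nucleic acid for binding affinity to Salmon testes DNA (Salmonidae), tested at 10 uM; on this read-out higher numbers stand for stronger stabilisation of the target against heat and lower numbers for weaker stabilisation of the target. Compound 1 `CC(C)CCc1sc(NC(=O)c2cc(NC(=O)c3cc(NC(=N)c4cnc5ccccc5c4)cn3C)cn2C)nc1C(=O)NCCCN(C)C` gives 2 degrees C. Compound 2 `CC(C)CCc1sc(NC(=O)c2cc(NC(=O)c3cc(NC(=N)c4ccc(F)cc4)cn3C)cn2C)nc1C(=O)NCCCN(C)C` gives 9 degrees C, and compound 3 `CC(C)CCc1sc(NC(=O)c2cc(NC(=O)c3cc(NC(=N)c4ccccc4)cn3C)cn2C)nc1C(=O)NCCCN(C)C` gives 7 degrees C. Among the three, compound 3 holds the second highest number: it lies a number 2.0 degrees C lower from compound 2 to compound 3 (beyond the scatter) and sits clearly above compound 1, as a number 5.0 degrees C higher from compound 1 to compound 3 (beyond the scatter) shows. The step from compound 3 to compound 4 `CC(C)CCc1sc(NC(=O)c2cc(NC(=O)c3cc(NC(=N)c4cccc(Cl)c4)cn3C)cn2C)nc1C(=O)NCCCN(C)C` consists of chloro in place of hydrogen on an aromatic carbon. For the measured compounds named here, one measured step bears directly on a halogen on this phenyl ring, namely a number 2.0 degrees C lower from compound 2 to compound 3 (beyond the scatter), so removing a fluoro cost a modest amount, and the fluoro-bearing compound 2 stands as the strongest of the three. The steps of a number 7.0 degrees C higher from compound 1 to compound 2 (beyond the scatter) and a number 5.0 degrees C higher from compound 1 to compound 3 (beyond the scatter) concern the larger replacement of quinolin-3-yl and say little about a single chloro. Whether chloro behaves like fluoro, and whether its different place on the ring matters, the measured compounds cannot tell. On this basis compound 4 is expected to show a modest gain, a number 1.0 degrees C higher from compound 3 to compound 4 (within the scatter), placing it near compound 2. Compound 4 is therefore estimated at 8 degrees C, with a range from 6 degrees C to 10 degrees C.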

Compound 4, shift of the target's melting temperature: 5 degrees C
Beside the measured number, compound 4's estimate is 3.0 degrees C above it, outside the stated range (below it).
By their numbers in this assay, from the lowest: compound 1; then compound 4; then compound 3; then compound 2.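

In this assay, a chloro on the phenyl ring lowers the number (a number 2.0 degrees C lower from compound 3 to compound 4 (beyond the scatter)), so the upward step seen earlier with a fluoro on this ring does not carry over to every halogen on it. The 3-chlorophenyl group also falls short of 4-fluorophenyl (a number 4.0 degrees C lower from compound 2 to compound 4 (beyond the scatter)), which shows that these two halogen-bearing rings are not interchangeable at this position, although they differ both in the halogen and in where it sits, while it still stays ahead of quinolin-3-yl (a number 3.0 degrees C higher from compound 1 to compound 4 (beyond the scatter)). No accompanying measurement bears on what lies behind the lower number.

Whether the drop belongs to chloro itself or to its place on the ring remains open, as the compounds shown carry each halogen at one place only. Also open, going by these compounds, is how a methyl, a methoxy or an amine on the same aromatic carbon would compare with the hydrogen of compound 3, and so whether any group there other than fluoro raises the number.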